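This account rests on a few compounds, and the source may have more. Where it says the series, first, only, none or still open, it means among the compounds named here.

Compound 1 `Cc1cc(N2CCCC2)nc2ccc(NC(=O)c3ccc(Cl)c(Cl)c3)cc12` gives 43400 nM in a functional assay on SK-BR-3 cells (Homo sapiens) for antiproliferative activity, read by MTT assay, with a stated time of 72 h; a higher number here means a weaker inhibitor, a lower number a stronger inhibitor. Compound 2 `Cc1cc(N(C)C)nc2ccc(NC(=O)c3ccc(Cl)c(Cl)c3)cc12` returns only the assay limit > 50000 nM in this assay, so its number is not known. The step of an at least 1.1-fold higher number from compound 1 to compound 2 (0.06 log units; that floor lies within the scatter) is an open-ended value rather than a measured difference, as the limit line the limit of > 50000 nM in this assay, at which 1 of the 2 values shown sits, shows. Compound 3 `CCN1CCN(c2cc(C)c3cc(NC(=O)c4ccc(Cl)c(Cl)c4)ccc3n2)CC1` carries 4-ethylpiperazin-1-yl in place of dimethylamino on an aromatic carbon. Among the measured compounds shown here, no measured step covers this exchange; the only related pair, compound 1 to compound 2, swaps ring and chain amines within the scatter. A modest improvement is expected for compound 3, an at least 1.6-fold lower number from compound 2 to compound 3 (0.22 log units; that floor lies within the scatter), giving an estimate of 30000 nM between 8000 nM and 50000 nM.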

Compound 3, half-maximal inhibitory concentration: 2160 nM
The estimate for compound 3 lay 14-fold (1.14 log units) above the measured number; measured number outside the range, below it.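

In this assay, 4-ethylpiperazin-1-yl next to the ring nitrogen gives a 20-fold lower number from compound 1 to compound 3 (1.30 log units; beyond the scatter), so the group at this position can move the number beyond the scatter, which the swap between pyrrolidin-1-yl and dimethylamino did not show. Against dimethylamino, the same group gives an at least 23-fold lower number from compound 2 to compound 3 (1.36 log units; beyond the scatter), a floor and not a measured size. That floor is set by the limit of compound 2: the limit of > 50000 nM in this assay, at which 1 of the 3 values shown sits.

The ring, its second nitrogen and the ethyl group remain unseparated in the compounds shown. A morpholine ring, or a piperazine with a methyl group in place of the ethyl group, would separate these parts.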